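The source may report more compounds than this note shows. Statements on the series, on what has been measured and on what is new or still open speak of the compounds shown alone.

Working notes on the series, read in a functional assay on A-431 cells (Homo sapiens), read by propidium iodide staining, with a stated time of 24 h; a lower number here means that less compound is needed, a higher number that more compound is needed for the effect. Compound 3 (`c1ccc(-c2nnc(Nc3ccc4c(c3)OCCO4)[nH]2)c(NCc2ccncc2)c1`) gives > 10000 nM, which is a limit of the assay and not a number. Compound 1 (`CS(=O)(=O)c1ccc(-c2nnc(-c3cccnc3NCC3COCCO3)[nH]2)cc1`) gives > 10000 nM, which is also a limit. Compound 3 therefore stands at the limit of > 10000 nM in this assay, at which 2 of the 3 values shown sit. Going by the values given here, compound 2 (`c1ccc(-c2nnc(Nc3ccc4c(c3)OCCO4)o2)c(NCc2ccncc2)c1`) gives 9 nM, the only true number among the three measured compounds.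

Compound 4 (`c1ccc(-c2nnc(Nc3ccc4c(c3)OCCO4)[nH]2)c(NCc2ccc3ncccc3c2)c1`) has quinolin-6-yl in place of pyridin-4-yl on a saturated chain carbon bound to a nitrogen on an aromatic ring. Among the compounds with values here, no measured pair shows this change, so the expectation in this assay is for no step beyond the scatter, with a slight chance of a move toward lower concentrations. This expectation starts from compound 3 at > 10000 nM, a limit. The estimated change is a number no higher from compound 3 to compound 4 (the limit leaves the size open). For compound 4 the expected value is 10000 nM, with an estimated range from 2000 nM to 30000 nM. A report of a limit alone is more likely than a true number.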

Compound 4, half-maximal effective concentration: > 10000 nM
Compound 4: a limit, no number; the forecaster's own chance of this, stated with the estimate: 65%; the middle value lies on the limit itself.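

Compound 3 and compound 4 both stand at a limit of the assay and not at a number, so no step can be read between them. The compounds shown leave open whether quinolin-6-yl in place of pyridin-4-yl changes the concentration needed at all.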